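Dichlorophenyl change from compound 2 to compound 3

The source may hold more compounds than are shown below. What is called first, only, known or untested is meant among the compounds shown, and "the series" means these compounds.

Values in an ADME assay on MT4 cells (Homo sapiens) for cytotoxicity, read by MTT assay; on this read-out higher numbers stand for lower toxicity in this test and lower numbers for higher toxicity in this test:
- compound 1 `Cc1ccccc1C(=O)N(C(=S)OCCN1C(=O)c2ccccc2C1=O)c1ccc(Cl)cc1`: 21000 nM
- compound 2 `O=C1c2ccccc2C(=O)N1CCOC(=S)N(C(=O)c1c(Cl)cccc1Cl)c1ccc(Cl)cc1`: 20000 nM

Compound 2 stands level with compound 1, within the scatter. Compound 3 `O=C1c2ccccc2C(=O)N1CCOC(=S)N(C(=O)c1ccc(Cl)c(Cl)c1)c1ccc(Cl)cc1` differs from compound 2 as follows: 3,4-dichlorophenyl in place of 2,6-dichlorophenyl on a carbonyl carbon. For the measured compounds named here, one measured step bears on this place on a carbonyl carbon: a 1.1-fold lower number from compound 1 to compound 2 (0.02 log units; within the scatter). Going by the values given here, that step, 2,6-dichlorophenyl in place of 2-methylphenyl, stayed within the scatter, but no measured compound carries 3,4-dichlorophenyl. No change beyond the scatter is therefore expected in this assay, in either direction. The expected step is no change at the digits printed from compound 2 to compound 3 (within the scatter). Compound 3 is estimated at 20000 nM, with an expected range of 10000 nM to 40000 nM.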

Compound 3, half-maximal cytotoxic concentration: 35000 nM
For compound 3 the middle estimate is 1.8-fold (0.24 log units) below the measured one; the range from low to high includes it.
By their numbers in this assay, from the lowest: compounds 2, 1 and 3 (each within the scatter of the next).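

In this assay, 3,4-dichlorophenyl on a carbonyl carbon stays within the scatter of both earlier groups: against 2,6-dichlorophenyl (a 1.8-fold higher number from compound 2 to compound 3 (0.24 log units; within the scatter)) and against 2-methylphenyl (a 1.7-fold higher number from compound 1 to compound 3 (0.22 log units; within the scatter)). Moving the two chlorines around the phenyl ring therefore gives no step beyond the scatter, and the three aryl groups at this place cannot be ranked. No measurement on hand bears on this result.

Open, from the compounds shown here alone, is whether any group at this place moves the number beyond the scatter. A carboxylic acid on the phenyl ring, an amine or a longer chain in place of the phenyl would test this.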